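Two Limits and a Five-Membered Ring on the Sulfonamide

The source may hold more compounds than are shown below. What is called first, only, known or untested is meant among the compounds shown, and "the series" means these compounds.

Compound 2 `Cc1cc(C)nc(NS(=O)(=O)c2ccc(NC3=C(Cl)C(=O)c4ccccc4C3=O)cc2)n1` and compound 1 `O=C1C(Cl)=C(Nc2ccc(S(=O)(=O)Nc3cnn(-c4ccccc4)c3)cc2)C(=O)c2ccccc21` share one core and differ only in the ring carried on the sulfonamide nitrogen. In a physicochemical assay for acid dissociation, compound 1 gives < 7.91, which is a limit of the assay and not a number. In this assay compound 2 likewise gives < 7.91, again a limit rather than a measured value. The step that the two limits leave unreadable from compound 1 to compound 2 therefore cannot be read, and compound 2 stands nowhere more precisely than at the same limit, as the limit of < 7.91 in this assay, at which 2 of the 2 values shown sit, records.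

Compound 3 `Cc1noc(NS(=O)(=O)c2ccc(NC3=C(Cl)C(=O)c4ccccc4C3=O)cc2)c1C` is not yet measured. It differs from compound 2 in one place: 3,4-dimethyl-1,2-oxazol-5-yl in place of 4,6-dimethylpyrimidin-2-yl on a sulfonamide nitrogen. No measured step bears on this change, since the only step shown is unreadable. The expectation for compound 3 rests on compound 2 alone, whose value < 7.91 is a limit. Compound 3 is estimated to give 5.6 in this assay, within a range from 4.6 to 6.9. The expected step that the limit leaves unreadable from compound 2 to compound 3 is thus downward from the limit, and the estimate remains uncertain.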

Compound 3, acid dissociation constant: < 7.91
Compound 3 gave a limit, no number; the forecaster's own chance of this, stated with the estimate: 20%; the middle value lies beyond the limit too.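

In this assay compound 3 gives < 7.91, which is a limit of the assay and not a number. Among the compounds shown here, no step among compound 1, compound 2 and compound 3 can therefore be read, and all three stand at one value: the limit of < 7.91 in this assay, at which 3 of the 3 values shown sit. The compounds shown leave open where their true values lie and whether changing the ring on the sulfonamide nitrogen shifts them at all.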